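The compounds below may be only part of what the source reports. "The series", "measured", "known", "first", "only" and "open" are said of these compounds alone.

The measured compounds are these three. Compound 1 is `CCCCNC(=O)NCc1ccc(CCCC)n(Cc2ccc(-c3ccccc3-c3nn[nH]n3)cc2)c1=O`; in a functional assay (aorta) for antagonist activity, with Oryctolagus cuniculus as the target (a higher number here means a weaker inhibitor, a lower number a stronger inhibitor), compound 1 gives 10 nM. Compound 2 is `CCCCc1ccc(CN(C)S(=O)(=O)c2ccccc2)c(=O)n1Cc1ccc(-c2ccccc2-c2nn[nH]n2)cc1`; in this assay compound 2 gives 2 nM. Compound 3 is `CCCCc1ccc(CN(C)S(C)(=O)=O)c(=O)n1Cc1ccc(-c2ccccc2-c2nn[nH]n2)cc1`; in this assay compound 3 gives 0.2 nM.

Compound 1 has the highest number of the three. Its nearest neighbour is compound 2, with a 5.0-fold lower number from compound 1 to compound 2 (0.70 log units; beyond the scatter), and its furthest is compound 3, with a 50-fold lower number from compound 1 to compound 3 (1.70 log units; beyond the scatter). Between the two sulfonamides the step is a 10-fold lower number from compound 2 to compound 3 (1.00 log units; beyond the scatter).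

Compound 4 is `CCCCc1cccc(=O)n1Cc1ccc(-c2ccccc2-c2nn[nH]n2)cc1`. It differs from compound 1 in one place: hydrogen in place of ((butylcarbamoyl)amino)methyl on an aromatic carbon. The two measured steps from compound 1 each exchange the group on that carbon for a methyl(sulfonyl)amino group, with a phenyl or a methyl on the sulfonyl sulfur, and both lower the number well beyond the scatter. Within the data shown here, no measured step removes the group outright and puts a hydrogen in its place, so neither step bears directly on compound 4; they show only that this position answers strongly to what sits there. With nothing left on that carbon, compound 4 is expected to give a higher number than compound 1, a step estimated at a 10-fold higher number from compound 1 to compound 4 (1.00 log units; beyond the scatter). The estimate for compound 4 in this assay is 100 nM, expected to lie between 15 nM and 1000 nM.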

Compound 4, half-maximal inhibitory concentration: 4 nM
Compound 4: middle estimate off by 25-fold (1.40 log units), on the high side; the whole stated range lies above it.
By their numbers in this assay, from the lowest: compound 3; then compounds 2 and 4 (each within the scatter of the next); then compound 1.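

Among these compounds, compound 4 shows that this aromatic carbon needs no substituent for a low number in this assay: replacing ((butylcarbamoyl)amino)methyl with hydrogen gives a 2.5-fold lower number from compound 1 to compound 4 (0.40 log units; beyond the scatter), so the group in compound 1 costs strength relative to bare hydrogen, something the earlier compounds could not reveal. With hydrogen as the reference, the three groups on this carbon now separate clearly, and only the (methyl(methylsulfonyl)amino)methyl group of compound 3 brings a real gain over hydrogen, as hydrogen in its place gives a 20-fold higher number from compound 3 to compound 4 (1.30 log units; beyond the scatter). Among the compounds shown here, the (methyl(phenylsulfonyl)amino)methyl group of compound 2 brings no such gain, as hydrogen in its place gives a 2.0-fold higher number from compound 2 to compound 4 (0.30 log units; within the scatter), so the large effect seen among the earlier compounds reflects both a penalty from one group and a benefit from another, rather than a benefit from sulfonamides in general.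

The compounds shown leave open whether a smaller group on this carbon, such as a plain methyl, a hydroxymethyl, an aminomethyl or a carboxylic acid, would also improve on hydrogen, and whether an ethyl on the sulfonyl sulfur would keep the gain seen with methyl. Nothing given here accounts for any of these differences.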